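Removing the Methyl from the Methoxy Group

This account rests on a few compounds, and the source may have more. Where it says the series, first, only, none or still open, it means among the compounds named here.

For the measured compounds named here, compound 2, with structure `COc1cc(-c2nn(-c3cccc(NC(=O)Nc4ccc(Cl)c(C(F)(F)F)c4)c3)cc2-c2ccncc2)ccc1Cl`, sits at the highest of the two numbers measured so far in a functional assay on OVCAR-3 cells (Homo sapiens) for inhibition, read by sulforhodamine B assay, with a stated time of 48 h (a lower number here means a stronger inhibitor of growth, a higher number a weaker inhibitor of growth), giving 889 nM. Its nearest neighbour, compound 1 with structure `COc1cc(-c2nn(-c3cccc(NC(=O)Nc4cccc(C(F)(F)F)c4)c3)cc2-c2ccncc2)ccc1Cl`, gives 579 nM, and the step of a 1.5-fold higher number from compound 1 to compound 2 (0.19 log units; within the scatter) keeps the two within the scatter of the measurement. The next compound, compound 3 with structure `O=C(Nc1cccc(-n2cc(-c3ccncc3)c(-c3ccc(Cl)c(O)c3)n2)c1)Nc1ccc(Cl)c(C(F)(F)F)c1`, differs from compound 2 in one place: hydrogen in place of methyl on an oxygen on an aromatic ring. Going by the values given here, the only step measured so far concerns chloro in place of hydrogen on an aromatic carbon, a different kind of change at a different place, so no measured step bears directly on this one. Among the compounds with values here, with no precedent, the expectation for compound 3 is a step of a 1.0-fold higher number from compound 2 to compound 3 (0.01 log units; within the scatter) that stays within the scatter. The estimated value for compound 3 is 900 nM, expected to lie between 350 nM and 2500 nM.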

Compound 3, concentration for 50% growth inhibition: 830 nM
Compound 3: middle estimate off by 1.1-fold (0.04 log units), on the high side; measured number inside the range.
By their numbers in this assay, from the lowest: compounds 1, 3 and 2 (each within the scatter of the next).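

In this assay, hydrogen in place of methyl on this oxygen, which turns methoxy into hydroxy, gives a 1.1-fold lower number from compound 2 to compound 3 (0.03 log units; within the scatter). For the compounds shown here, this is the first measured change at this oxygen, and it shows that the methyl can go without any change that this measurement can detect, so growth inhibition here does not depend on that one carbon. Nothing available explains why the two numbers stay so close.

Going by these compounds, it remains open whether a longer chain on this oxygen, such as ethoxy, or an amine in place of the hydroxy would move the number beyond the scatter. On these data alone, it is also open whether the same change from methoxy to hydroxy would behave alike in compound 1, which lacks the added chloro.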